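This account rests on a few compounds, and the source may have more. Where it says the series, first, only, none or still open, it means among the compounds named here.

Measured so far in a functional assay on MCF7 cells (Homo sapiens) for antiproliferative activity, read by MTT assay, with a stated time of 48 h; on this read-out higher numbers stand for weaker inhibition and lower numbers for stronger inhibition:
compound 1, `N=C(N)N/N=C(/C=C/c1ccccc1Cl)c1ccccc1`: 4200 nM
compound 2, `N=C(N)N/N=C(/C=C/c1ccccc1Br)c1ccccc1`: 4200 nM
compound 3, `N=C(N)N/N=C(/C=C/c1ccccc1)c1ccc(Cl)cc1`: 350 nM

Compound 3 stands lowest of the three numbers; compound 1 and compound 2 both lie above it by margins beyond the scatter. Compound 1 and compound 3 have the same atoms joined differently; the difference between the two cores is not broken down here.

One change has already been measured on the core of compound 1: bromo in place of chloro on an aromatic carbon, which gave no change at the digits printed from compound 1 to compound 2 (within the scatter). Compound 4, `N=C(N)N/N=C(/C=C/c1ccccc1)c1ccc(Br)cc1`, remains to be measured in this assay. It arises from compound 3 by bromo in place of chloro on an aromatic carbon. This is the same kind of change as the earlier one, not the same: in compound 1 the group sits ortho to a large group, in compound 3 it sits para to a large group. The expected step from compound 3 to compound 4 is no change at the digits printed from compound 3 to compound 4 (within the scatter), an expectation that rests on no change at the digits printed from compound 1 to compound 2 (within the scatter). Compound 4 is accordingly estimated at 350 nM, between 150 nM and 800 nM.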

Compound 4, half-maximal inhibitory concentration: 90 nM
Beside the measured number, compound 4's estimate is 3.9-fold (0.59 log units) above it; measured number outside the range, below it.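

Bromo in place of chloro on an aromatic carbon does not carry over as a fixed step in this assay in this series: para to a large group, the change gives a 3.9-fold lower number from compound 3 to compound 4 (0.59 log units; beyond the scatter) on the core of compound 3. Set beside the same change on the core of compound 1, the two steps do not agree: the same change on two cores in this assay, no change at the digits printed (within the scatter) from compound 1 to compound 2 and a 3.9-fold lower number (0.59 log units; beyond the scatter) from compound 3 to compound 4, 3.9-fold (0.59 log units) apart, beyond the scatter of two such steps. This shows that the outcome of the change depends on its setting, but the two pairs differ both in the core and in where the group sits, so these two steps cannot separate one influence from the other and give no reason for the gap.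

Still open, as far as these compounds go, is whether the lower number on going to the 4-bromophenyl group is particular to bromo, or whether iodo, methyl, methoxy or an amine in the same place would read alike. Also open, from the compounds shown here alone, is how a carboxylic acid there would read, and whether any such group would behave differently on the core of compound 1.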